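Swapping a methoxyphenyl for a fused bicycle on the benzylic arm

The source may report more compounds than this note shows. Statements on the series, on what has been measured and on what is new or still open speak of the compounds shown alone.

Measured so far:
- compound 1, `CNC(=O)c1cc(C(=O)NC2CC2)cn(Cc2cccc(OC)c2)c1=O`: 3
- compound 2, `CNC(=O)c1cc(C(=O)NCCC2CCOCC2)cn(Cc2ccccc2)c1=O`: 3.6
- compound 3, `CNC(=O)c1cc(C(=O)NC2CCC2)cn(Cc2ccccn2)c1=O`: 2.2

Three compounds sharing the same core have been examined in a physicochemical assay for lipophilicity, at pH 7.4; on this read-out higher numbers stand for higher lipophilicity and lower numbers for lower lipophilicity. In this assay compound 1 gives 3. That puts compound 1 second highest of the three numbers: compound 2 stands higher than compound 1 by a margin beyond the scatter, and compound 3 stands lower than compound 1 by a margin also beyond the scatter. For the measured compounds named here, none of these three pairs differs in only one place, so no single step can be isolated among them.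

Compound 4, `CNC(=O)c1cc(C(=O)NC2CC2)cn(Cc2nccc3[nH]ccc23)c1=O`, has not yet been measured in this assay. It differs from compound 1 in one place: a group of 9 heavy atoms (7 carbon, 2 nitrogen; one five-membered aromatic ring with 1 hetero atom, one six-membered aromatic ring with 1 hetero atom) in place of a group of 8 heavy atoms (7 carbon, 1 oxygen; one six-membered aromatic ring of carbon only), on a saturated chain carbon bound to an aromatic nitrogen. Because compound 3, which carries a six-membered aromatic ring with one hetero atom on the same chain carbon, gives 2.2, a downward step is expected here, and one that is beyond the scatter rather than within it. Compound 4 is therefore expected to give 1.9 in this assay, within a range from 1.3 to 2.5. The expected step from compound 1 to compound 4 is a number 1.10 log units lower from compound 1 to compound 4 (beyond the scatter).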

Compound 4, distribution coefficient: 1.7
Compound 4: middle estimate off by 0.20 log units, on the high side; low and high end bracket the measured number.
By their numbers in this assay, from the lowest: compound 4; then compound 3; then compound 1; then compound 2.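

In this assay, replacing the 3-methoxyphenyl with the entering two-ring group on a saturated chain carbon bound to an aromatic nitrogen gives a number 1.30 log units lower from compound 1 to compound 4 (beyond the scatter), a large step. For the compounds shown here, it is the first step that can be read in one place, as the three earlier compounds all differ from each other in more than one place, and it shows that this position alone can move the number well beyond the scatter with the rest of compound 1 unchanged. The change swaps a group with no hydrogen-bond donor for one with a donor and also alters the ring types, but no measurement here explains the step or separates these features.

The compounds shown leave open which feature of the entering group accounts for the step, a question that a methyl on the nitrogen of its five-membered ring or an indole on the same chain carbon would address. They also leave open whether a step of this size would recur with the same exchange on a compound carrying a cyclobutyl amide or a longer chain in place of the cyclopropyl amide.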